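Quinoline ether amides: lipophilicity on the way to compound 4

A few compounds are considered here, and "the series" means these few. Any claim that something is new, unique, unknown or untested is made for them only; others in the source may bear on it.

Compound 1 `CSc1ccc2nc(C)cc(OCC(=O)Nc3cc(C)cc(C)c3)c2c1`: 6.42
Compound 2 `Cc1cc(C)cc(NC(=O)COc2cc(C)nc3ccc(Cl)cc23)c1`: 6.38
Compound 3 `COc1ccc2nc(C)cc(OCC(=O)Nc3ccc(Br)c(C)c3)c2c1`: 5.95

In a physicochemical assay for lipophilicity, read by HPLC, in phosphate buffer, measured as chromatographic lipophilicity, at pH 7.4 (a higher number here means a more lipophilic compound, a lower number a more polar compound), compound 3 gives the lowest of the three numbers, with compound 2 giving 6.38 and compound 1 giving 6.42. The unmeasured compound 4 `COc1ccc2nc(C)cc(OCC(=O)NNC(=O)c3ccncc3)c2c1` arises from compound 3 by the change (((pyridin-4-yl)carbonyl)amino in place of 4-bromo-3-methylphenyl on an amide-type nitrogen). Among the compounds with values here, the only measured step, a number 0.04 log units lower from compound 1 to compound 2 (within the scatter), concerns an aromatic carbon, not the amide-type nitrogen, so it does not bear on this change. The entering group differs from the leaving group in every counted respect, and the step is expected to be large. Compound 4 is therefore estimated at 3 in this assay, within 2.2 to 3.8, a step of a number 2.95 log units lower from compound 3 to compound 4 (beyond the scatter).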

Compound 4, distribution coefficient: 1.48
Estimate against measurement, compound 4: 1.52 log units above, and the stated range ends above it.
By their numbers in this assay, from the lowest: compound 4; then compound 3; then compounds 2 and 1 (each within the scatter of the next).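

On the amide-type nitrogen, ((pyridin-4-yl)carbonyl)amino in place of 4-bromo-3-methylphenyl gives, in this assay, a number 4.47 log units lower from compound 3 to compound 4 (beyond the scatter), the first step shown at this position and a large one, whereas the earlier step on an aromatic carbon stayed within the scatter. The change alters the ring, adds a carbonyl and brings in a hydrogen-bond donor all at once, so the step belongs to the whole exchange and not to any one part of it. Nothing in the data accounts for the size of this step.

Which part of the exchange carries the step stays open. A benzoylamino group or a plain pyridin-4-yl on that same nitrogen would separate the ring hetero atom from the carbonyl and amino link.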